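The source may report more compounds than this note shows. Statements on the series, on what has been measured and on what is new or still open speak of the compounds shown alone.

Compound 1 `O=C(/C=C/c1ccc2c(c1)B(O)OC2)c1ccccc1` is the reference point of the pair measured so far. In a functional assay on HCT-116 cells (Homo sapiens) for cytotoxicity, read by MTT assay, with a stated time of 48 h (on this read-out lower numbers stand for stronger inhibition and higher numbers for weaker inhibition), compound 1 gives 6100 nM, the lowest of the two numbers, with compound 2 `O=C(/C=C/c1ccc2c(c1)B(O)OC2)c1ccc([N+](=O)[O-])cc1` nearest: in this assay compound 2 gives 9100 nM, and the change a 1.5-fold higher number from compound 1 to compound 2 (0.17 log units; within the scatter) is nitro in place of hydrogen on an aromatic carbon. Compound 3 `CCOC(=O)c1ccc(C(=O)/C=C/c2ccc3c(c2)B(O)OC3)cc1` carries a different substituent on the same aryl carbon: ethoxycarbonyl in place of hydrogen on an aromatic carbon. Among the compounds with values here, the only measured step that bears on this change is the one from compound 1 to compound 2, a substituent entering at the same place, and it stayed within the scatter. No other substitution on that ring has been tested, so nothing points to a step beyond the scatter in either direction. For compound 3 the number in this assay is expected to stay near compound 1, the step of a 1.2-fold higher number from compound 1 to compound 3 (0.09 log units; within the scatter) being an estimate. Compound 3 is therefore estimated at 7500 nM, with a range from 3500 nM to 16000 nM.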

Compound 3, half-maximal inhibitory concentration: 7600 nM
Beside the measured number, compound 3's estimate is 1.0-fold (0.01 log units) below it; measured number inside the range.
By their numbers in this assay, from the lowest: compounds 1, 3 and 2 (each within the scatter of the next).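

With ethoxycarbonyl, a group of 5 heavy atoms with no ring, a second substituent on this aromatic carbon now stays within the scatter of hydrogen in this assay (a 1.2-fold higher number from compound 1 to compound 3 (0.10 log units; within the scatter)). Within the data shown here, the exchange of one substituent for the other is also within the scatter (a 1.2-fold lower number from compound 2 to compound 3 (0.08 log units; within the scatter)), so hydrogen, nitro and ethoxycarbonyl cannot be told apart at this position in this assay, which the single earlier step could not show. No measurement on hand offers an explanation for this result.

Still open, going by these compounds, is whether an amine, a carboxylic acid or a longer ester chain on this aromatic carbon would produce a step beyond the scatter. The compounds shown also leave open how far any change to the shared core would move the number.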